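A Methyl Group Added to Compound 2

The source may hold more compounds than are shown below. What is called first, only, known or untested is meant among the compounds shown, and "the series" means these compounds.

Measured in a functional assay on the whole organism (Hindlimb, strain albino) with Mus musculus as the target, in the maximal electroshock model, with a stated time of 0.5 h; on this read-out lower numbers stand for an effect already at smaller amounts and higher numbers for an effect only at larger amounts of compound:
- Compound 1 `Cc1ccc2nc(NC(=O)/C=C/c3ccc(O)cc3)sc2c1`: 271 umol/kg
- Compound 2 `COc1ccc(/C=C/C(=O)Nc2nc3ccccc3s2)cc1`: 435 umol/kg

Only these two compounds have been measured, and their values lie within the scatter of each other, so compound 2 cannot be ranked against compound 1. Compound 3 `COc1ccc(/C=C/C(=O)Nc2nc3ccc(C)cc3s2)cc1` is compound 2 with methyl in place of hydrogen on an aromatic carbon. For the measured compounds named here, no measured pair isolates this change. Compound 1 also carries a methyl on the core and gives 271 umol/kg, but it differs from compound 2 in more than one place, so it offers only weak guidance. No change beyond the scatter is therefore expected, and the expected step of a 1.3-fold lower number from compound 2 to compound 3 (0.11 log units; within the scatter) is small. For compound 3 the estimated value is 340 umol/kg, with an expected range from 160 umol/kg to 720 umol/kg.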

Compound 3, dose for half-maximal effect: 209 umol/kg
Estimate against measurement, compound 3: 1.6-fold (0.21 log units) above, and the stated range covers the measured number.
By their numbers in this assay, from the lowest: compounds 3, 1 and 2 (each within the scatter of the next, the first and the last beyond it).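

For the compounds shown here, with compound 3, methyl in place of hydrogen on an aromatic carbon is isolated for the first time: in this assay the change gives a 2.1-fold lower number from compound 2 to compound 3 (0.32 log units; beyond the scatter), a modest step on this carbon of the fused system. The other single-place comparison, a 1.3-fold lower number from compound 1 to compound 3 (0.11 log units; within the scatter), shows that, with this core methyl present, methyl in place of hydrogen on the oxygen on the aromatic ring gives no separable difference. Nothing available accounts for the step at the core methyl.

The compounds shown leave open whether an ethyl group, a chlorine atom or an amine on this carbon would give a step of similar size. They also leave open whether methyl would do the same on another carbon of that ring.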